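This account rests on a few compounds, and the source may have more. Where it says the series, first, only, none or still open, it means among the compounds named here.

The series shares one core, seen in compound 1 (`Cc1ccc(CC(C)(Oc2ccc(C(C)C)cc2)C(=O)O)cc1`), compound 2 (`CC(C)c1ccc(CC(C)(Oc2ccc(C(C)C)cc2)C(=O)O)cc1`), compound 3 (`COc1ccccc1CC(C)(Oc1ccc(C(C)C)cc1)C(=O)O`) and the unmeasured compound 4 (`COc1ccc(CC(C)(Oc2ccc(C(C)C)cc2)C(=O)O)cc1`). In a functional assay on the whole organism for inhibition, with Rattus norvegicus as the target (a lower number here means that less compound is needed, a higher number that more compound is needed for the effect), compound 1 gives < 1 mg/kg, which is a limit of the assay. Compound 2 gives 5 mg/kg, a true number. Going by these compounds, compound 3 gives > 10 mg/kg, which is also a limit, so its exact place is unknown.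

The next change is 4-methoxyphenyl in place of 2-methoxyphenyl on a saturated chain carbon, two bonds along the chain from a carbonyl carbon and an oxygen on an aromatic ring.

Among the compounds with values here, two measured steps bear on it. The step that brought in the 2-methoxyphenyl, an at least 10-fold higher number from compound 1 to compound 3 (1.00 log units; beyond the scatter), lies beyond the scatter. So does an at least 5.0-fold higher number from compound 1 to compound 2 (0.69 log units; beyond the scatter), which shows that the number in this assay also moves with the group on the ring. Neither step tests the 4-methoxyphenyl directly.

A modest step towards a lower number is expected, estimated as an at least 3.3-fold lower number from compound 3 to compound 4 (0.52 log units; beyond the scatter). For compound 4 the estimated value in this assay is 3 mg/kg, with an expected range of 0.8 mg/kg to 12 mg/kg.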

Compound 4, dose for half-maximal effect: > 10 mg/kg
Compound 4 was reported as a limit (the forecaster's own chance of this, stated with the estimate: 35%); middle value at least 3.3-fold (0.52 log units) away from the limit.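

In this assay, the 4-methoxyphenyl does not bring the series off the upper limit: compound 4 gives > 10 mg/kg, which is a limit of the assay. The step to compound 3 cannot be read because both compounds sit at the same limit: the limit of > 10 mg/kg in this assay, at which 2 of the 4 values shown sit.

With the methoxy group now tested against the alkyl groups, methoxy in place of methyl gives an at least 10-fold higher number from compound 1 to compound 4 (1.00 log units; beyond the scatter), while methoxy in place of isopropyl gives an at least 2.0-fold higher number from compound 2 to compound 4 (0.30 log units; that floor lies within the scatter), so only the first step is certain to exceed the scatter.

The compounds shown leave open how far compound 3 and compound 4 lie past the limit, and so whether moving the methoxy group changes the number at all. Also open, going by these compounds, is where a 4-ethylphenyl or 4-chlorophenyl would fall in this assay.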